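The compounds below may be only part of what the source reports. "The series", "measured", "known", "first", "only" and "open" are said of these compounds alone.

Measured in a functional assay on NCI-H3122 cells (Homo sapiens) for inhibition, read by CellTiter-Glo, with a stated time of 72 h; a higher number here means a weaker inhibitor of growth, a lower number a stronger inhibitor of growth:
- compound 1 `C=CC(=O)Nc1cc(Nc2ncc(Cl)c(Nc3ccccc3S(=O)(=O)C(C)C)n2)c(OC)cc1N1CCN(C)CC1`: 33 nM
- compound 2 `C=CC(=O)Nc1cc(Nc2ncc(Cl)c(Nc3ccc(F)c(Cl)c3)n2)c(OC)cc1N1CCN(C)CC1`: 300 nM
- compound 3 `C=CC(=O)Nc1cc(Nc2ncc(Cl)c(NCc3cccs3)n2)c(OC)cc1N1CCN(C)CC1`: 270 nM

Compound 3 stands second highest of the three numbers; its nearest neighbour is compound 2, and the gap between them, a 1.1-fold lower number from compound 2 to compound 3 (0.05 log units; within the scatter), is within the scatter. Going by the values given here, the only compound clearly apart is compound 1, and the step of an 8.2-fold higher number from compound 1 to compound 3 (0.91 log units; beyond the scatter) is beyond the scatter.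

The next compound, compound 4 `C=CC(=O)Nc1cc(Nc2ncc(Cl)c(NC3CC3)n2)c(OC)cc1N1CCN(C)CC1`, has not yet been measured in this assay. It differs from compound 3 in one place: cyclopropyl in place of (thiophen-2-yl)methyl on a nitrogen on an aromatic ring.

Among the compounds with values here, no measured step replaces the (thiophen-2-yl)methyl with a cyclopropyl, so none bears on this change directly. What the series shows is that the two groups so far placed on this nitrogen in place of the 2-(isopropylsulfonyl)phenyl, in compound 2 and compound 3, give numbers within the scatter of each other, while both steps away from compound 1, a 9.1-fold higher number from compound 1 to compound 2 (0.96 log units; beyond the scatter) and an 8.2-fold higher number from compound 1 to compound 3 (0.91 log units; beyond the scatter), are modest and beyond the scatter. The cyclopropyl is the smallest group tried on this nitrogen and nothing in the series speaks for it recovering the number of compound 1.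

Compound 4 is therefore expected to give a number near or somewhat higher than compound 3, with the step of a 1.7-fold higher number from compound 3 to compound 4 (0.22 log units; within the scatter) estimated at or just beyond the scatter.

The estimate for compound 4 in this assay is 450 nM, within 150 nM to 1400 nM.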

Compound 4, concentration for 50% growth inhibition: 3200 nM
Compound 4: the middle estimate sits 7.1-fold (0.85 log units) below what was measured; the measured number lies above the stated range.
By their numbers in this assay, from the lowest: compound 1; then compounds 3 and 2 (each within the scatter of the next); then compound 4.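

In this assay the groups on a nitrogen on an aromatic ring are not interchangeable: a 12-fold higher number from compound 3 to compound 4 (1.07 log units; beyond the scatter) and an 11-fold higher number from compound 2 to compound 4 (1.03 log units; beyond the scatter) show that the agreement within the scatter between the (thiophen-2-yl)methyl and the 3-chloro-4-fluorophenyl does not extend to the cyclopropyl. Set against the 2-(isopropylsulfonyl)phenyl, the same position gives a 97-fold higher number from compound 1 to compound 4 (1.99 log units; beyond the scatter) and this is the widest step in the series, so the position spans a far greater range than the first three compounds showed, with compound 4 apart from all of them and beyond the scatter of each. Going by these compounds alone, the cyclopropyl is the only group here without an aromatic ring and also has the fewest heavy atoms, and compound 4 alone cannot separate these two differences.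

Going by these compounds, whether a phenyl without substituents, a cyclohexyl or a longer carbon chain on this nitrogen would follow compound 4 or compounds 2 and 3 remains open. Nothing at hand gives a reason for the size of these steps.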